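Amide series on pancreatic cell proliferation

The compounds below may be only part of what the source reports. "The series", "measured", "known", "first", "only" and "open" are said of these compounds alone.

Measured so far:
- compound 1, `Cc1nn(Cc2ccccc2)c(C)c1NC(=O)c1ccc(COc2ccccc2)cc1`: 10000 nM
- compound 2, `CNC(=O)c1cccc(Cn2nc(C)c(NC(=O)c3ccc(COc4ccc(OC)cc4)cc3)c2C)c1`: 8000 nM

Both numbers come from a functional assay on MIA PaCa-2 cells (Homo sapiens) for antiproliferative activity, read by MTT assay, with a stated time of 72 h; on this read-out lower numbers stand for an effect already at smaller amounts and higher numbers for an effect only at larger amounts of compound. Compound 1 gives 10000 nM and compound 2 gives 8000 nM; the gap between them lies within the scatter, so neither can be called the more potent of the two. Compound 2 holds the lowest of the two numbers, with compound 1 as its nearest neighbour.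

Compound 3, `CNC(=O)c1cccc(Cn2nc(C)c(NC(=O)c3ccc(COc4ccc(C(F)(F)F)cc4C)cc3)c2C)c1`, has not been measured. It differs from compound 2 in one place: 2-methyl-4-(trifluoromethyl)phenyl in place of 4-methoxyphenyl on an oxygen on a saturated carbon. Among the measured compounds shown here, no step between measured compounds touches this position, so nothing in the two values shown says how this part of the molecule matters in this assay. For that reason the step is expected to be modest, if anything a small move toward lower numbers, with a real chance of none beyond the scatter: the estimated step is a 1.6-fold lower number from compound 2 to compound 3 (0.20 log units; within the scatter). For compound 3 in this assay the estimate is 5000 nM, within 1500 nM to 15000 nM.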

Compound 3, half-maximal effective concentration: 620 nM
Compound 3: the middle estimate sits 8.1-fold (0.91 log units) above what was measured, and the stated range ends above it.
By their numbers in this assay, from the lowest: compound 3; then compounds 2 and 1 (each within the scatter of the next).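

In this assay, among the compounds shown here, the group on the oxygen on a saturated carbon proves able to move the number: 2-methyl-4-(trifluoromethyl)phenyl in place of 4-methoxyphenyl gives a 13-fold lower number from compound 2 to compound 3 (1.11 log units; beyond the scatter) and is the first step that lies beyond the scatter. The earlier compounds shown here could not show this, as no step between them touched this position, and the rest of the molecule stays the same across this change, so the gain belongs to this one exchange of aryl groups. No measurement at hand bears on why the number moves.

The step removes the methoxy group and brings in both the methyl and the trifluoromethyl group at once, so the compounds shown cannot divide it among these three parts, and it remains open whether 4-(trifluoromethyl)phenyl without the methyl, or 2-methylphenyl alone, would account for most of it. Also open, going by these compounds, is how far this position tolerates other groups, such as a nitrile, a chlorine atom or an amine in place of the trifluoromethyl group.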